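A few compounds are considered here, and "the series" means these few. Any claim that something is new, unique, unknown or untested is made for them only; others in the source may bear on it.

Measured so far in an assay on isolated protein for binding affinity to fibroblast growth factor 1 (Homo sapiens), read by surface plasmon resonance; on this read-out lower numbers stand for tighter binding and higher numbers for weaker binding:
- compound 1 `CCN(CC(=O)NC[C@H]1O[C@H](OC)[C@@H](OS(=O)(=O)O)[C@@H](OS(=O)(=O)O)[C@@H]1OS(=O)(=O)O)C(=O)COS(=O)(=O)O`: 174000 nM
- compound 2 `CCN(CC(=O)NC[C@H]1O[C@H](OC)[C@@H](OS(=O)(=O)O)[C@@H](OS(=O)(=O)O)[C@@H]1OS(=O)(=O)O)C(=O)CCCc1ccccc1`: 500000 nM

For the measured compounds named here, compound 2 gives the highest of the two numbers; its nearest neighbour is compound 1, and the only measured step, a 2.9-fold higher number from compound 1 to compound 2 (0.46 log units; beyond the scatter), is modest but beyond the scatter. Both compounds share the trisulfated methyl glycoside core; they differ solely in the terminal group of the acyl chain on the tertiary amide nitrogen.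

Compound 3 `CCN(CC(=O)NC[C@H]1O[C@H](OC)[C@@H](OS(=O)(=O)O)[C@@H](OS(=O)(=O)O)[C@@H]1OS(=O)(=O)O)C(=O)CCCCC(=O)O` is the next member. Its difference from compound 2 is carboxymethyl in place of phenyl on a saturated chain carbon, three bonds along the chain from a carbonyl carbon, so the acyl chain now ends in an acid instead of a phenyl ring. The step from compound 1 to compound 2 bears on this: removing the sulfooxy terminus and putting in a hydrocarbon terminus raised the number, and compound 3 moves partly back toward an acidic terminus, though with a carboxylic acid rather than a sulfate. The expected step of a 2.0-fold lower number from compound 2 to compound 3 (0.30 log units; within the scatter) is therefore modest and toward a lower number, likely landing between compound 1 and compound 2. For compound 3 the estimate in this assay is 250000 nM, with a range from 100000 nM to 600000 nM.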

Compound 3, dissociation constant: 160000 nM
Compound 3: the middle estimate sits 1.6-fold (0.19 log units) above what was measured, and the stated range covers the measured number.
By their numbers in this assay, from the lowest: compounds 3 and 1 (each within the scatter of the next); then compound 2.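

In this assay the chain end proves responsive to more than the loss of sulfooxy: carboxymethyl in place of phenyl, on a saturated chain carbon three bonds along the chain from a carbonyl carbon, gives a 3.1-fold lower number from compound 2 to compound 3 (0.49 log units; beyond the scatter) and so reverses a shift of about the same size as the one seen on entering the phenyl-ended chain. The sulfooxy group is also not required to reach the level of compound 1, as 3-carboxypropyl in its place gives a 1.1-fold lower number from compound 1 to compound 3 (0.04 log units; within the scatter) and that step lies within the scatter, leaving compound 2 as the only one of the three set apart from the others. No supporting data accompany these numbers to account for either step.

Compound 1 and compound 3 differ in chain length as well as in the terminal group, so the effect of each cannot be separated, and a sulfooxy group and a carboxylic acid remain uncompared on chains of equal length. From the compounds shown here alone, it also stays open whether an amine or a primary amide at the chain end would match the carboxylic acid or fall with the phenyl group, and whether a shorter or longer chain ending in a carboxylic acid would shift the number.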